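This account rests on a few compounds, and the source may have more. Where it says the series, first, only, none or still open, it means among the compounds named here.

Measured in a functional assay on NCI-H1299 cells (Homo sapiens) for inhibition, read by CCK-8 assay, with a stated time of 72 h, tested at 10 uM; on this read-out lower numbers stand for less inhibition of growth and higher numbers for more inhibition of growth at the one concentration tested:
- compound 1 `CN(C)C(=O)c1cc2cnc(Nc3ccc(NC(=O)C4(C(=O)Nc5cccc(Cl)c5)CC4)cc3)nc2n1C1CCCC1` gives 84.1%
- compound 2 `CN(C)C(=O)c1cc2cnc(Nc3ccc(NC(=O)C4(C(=O)Nc5ccc(Cl)c(C(F)(F)F)c5)CC4)cc3)nc2n1C1CCCC1` gives 90.4%
- compound 3 `Cc1ccc(NC(=O)C2(C(=O)Nc3ccc(Nc4ncc5cc(C(=O)N(C)C)n(C6CCCC6)c5n4)cc3)CC2)cc1` gives 84.5%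

Compound 3 cannot be separated from the other two, since the data show a number 0.4 percentage points higher from compound 1 to compound 3 (within the scatter) and a number 5.9 percentage points lower from compound 2 to compound 3 (within the scatter). Compound 4 `CN(C)C(=O)c1cc2cnc(Nc3ccc(NC(=O)C4(C(=O)Nc5ccc(O)cc5)CC4)cc3)nc2n1C1CCCC1` keeps all of compound 3 except one group: hydroxy in place of methyl on an aromatic carbon. This is hydroxy in place of methyl on an aromatic carbon, para to a large group.

The measured steps that bear on this change the same aryl group on the amide-type nitrogen. Besides the two above, there is a number 6.3 percentage points higher from compound 1 to compound 2 (within the scatter). Among the measured compounds shown here, none of them swaps methyl for hydroxy, and no measured compound carries a hydroxy group here, so they are only indirect evidence. Three different aryl groups have so far given values within the scatter of one another, so the expected change is small: a number 3.5 percentage points lower from compound 3 to compound 4 (within the scatter), which means no step beyond the scatter. The untested hydroxy group calls for a wide range. Compound 4 is estimated at 81%, with an expected range from 66% to 92%.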

Compound 4, percent growth inhibition at one concentration: 89.7%
Compound 4: middle estimate off by 8.7 percentage points, on the low side, and the stated range covers the measured number.
By their numbers in this assay, from the lowest: compounds 1, 3, 4 and 2 (each within the scatter of the next).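

In this assay, hydroxy is the only group shown at this place that adds a hydrogen-bond donor and acceptor, and the data give a number 5.2 percentage points higher from compound 3 to compound 4 (within the scatter), together with a number 0.7 percentage points lower from compound 2 to compound 4 (within the scatter) and a number 5.6 percentage points higher from compound 1 to compound 4 (within the scatter). Methyl can therefore give way to hydroxy on this aromatic carbon without a step beyond the scatter, and all four aryl groups on the amide-type nitrogen now stand within the scatter of one another at the single concentration tested. Nothing measured here explains this result.

From the compounds shown here alone, it remains open whether any group at this place would move the number beyond the scatter, such as an amine, a carboxylic acid or a methoxy group. These single-concentration numbers also cannot show whether the four compounds would separate at lower concentrations.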